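The compounds below may be only part of what the source reports. "The series", "measured", "known", "first", "only" and "open" are said of these compounds alone.

In an ADME assay on Vero cells (Chlorocebus sabaeus) for cytotoxicity, read by MTT assay, with a stated time of 48 h (a lower number here means a stronger inhibitor, a higher number a weaker inhibitor), compound 1 `CS(=O)(=O)NC1CCC(CN2CCN(c3cc(=O)c4cc(C(F)(F)F)cc([N+](=O)[O-])c4s3)CC2)CC1` gives 48.5 ug/mL. Compound 2 `O=C(OC1CCC(CN2CCN(c3cc(=O)c4cc(C(F)(F)F)cc([N+](=O)[O-])c4s3)CC2)CC1)c1ccncc1` reaches only a limit of the assay, > 64 ug/mL. Within the data shown here, the single measured step, an at least 1.3-fold higher number from compound 1 to compound 2 (0.12 log units; that floor lies within the scatter), alters a different part of the molecule, and because of the limit of > 64 ug/mL in this assay, at which 1 of the 2 values shown sits, its true size stays unknown. Compound 3 `O=C(OC1CCC(CN2CCN(c3cc(=O)c4cc(C(F)(F)F)cc([N+](=O)[O-])c4s3)CC2)CC1)c1ccc2ccccc2c1` differs from compound 2 by naphthalen-2-yl in place of pyridin-4-yl on a carbonyl carbon. Among the measured compounds shown here, no measured step touches this part, so no direction beyond the scatter is supported. Compound 3 is therefore expected to sit close to compound 2, with an estimated step of an at least 1.0-fold lower number from compound 2 to compound 3 (0.02 log units; that floor lies within the scatter). The estimate for compound 3 is 60 ug/mL, spanning 20 ug/mL to 150 ug/mL.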

Compound 3, half-maximal inhibitory concentration: > 64 ug/mL
Compound 3: only a limit was reported; the forecaster's own chance of this, stated with the estimate: 55%; at least 1.0-fold (0.02 log units) between middle value and limit.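

No step can be read from compound 2 to compound 3, because both results are limits rather than numbers: the limit of > 64 ug/mL in this assay, at which 2 of the 3 values shown sit. The compounds shown leave open whether swapping pyridin-4-yl for naphthalen-2-yl changes the true value at all.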